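This account rests on a few compounds, and the source may have more. Where it says the series, first, only, none or still open, it means among the compounds named here.

In a functional assay on MGC-803 cells (Homo sapiens) for inhibition, read by sulforhodamine B assay (a lower number here means a stronger inhibitor, a higher number a weaker inhibitor), compound 1 `O=C1C(NC2CCCC2)=CC(=O)c2c1nc1n2[C@H]2OC[C@@H](O)[C@H]2OC1` gives > 16000 nM, which is a limit of the assay. Going by the values given here, compound 2 `COc1ccc(NC2=CC(=O)c3c(nc4n3[C@H]3OC[C@@H](O)[C@H]3OC4)C2=O)cc1` gives 2150 nM, the only actual number so far. Among the compounds with values here, the one measured step, an at least 7.4-fold lower number from compound 1 to compound 2 (0.87 log units; beyond the scatter), replaced cyclopentyl with 4-methoxyphenyl on an amine nitrogen. Compound 3 `CCOc1ccccc1NC1=CC(=O)c2c(nc3n2[C@H]2OC[C@@H](O)[C@H]2OC3)C1=O` has 2-ethoxyphenyl in place of 4-methoxyphenyl at that nitrogen: 2-ethoxyphenyl in place of 4-methoxyphenyl on an amine nitrogen. Both groups are aryl, so an at least 7.4-fold lower number from compound 1 to compound 2 (0.87 log units; beyond the scatter) gives only weak guidance, and no change beyond the scatter is expected, in either direction. The expected change is a 1.2-fold higher number from compound 2 to compound 3 (0.07 log units; within the scatter). For compound 3 the estimated value in this assay is 2500 nM, with an expected range of 800 nM to 8000 nM.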

Compound 3, half-maximal inhibitory concentration: 2830 nM
Compound 3: middle estimate off by 1.1-fold (0.05 log units), on the low side, within the range that was stated.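

In this assay, 2-ethoxyphenyl in place of 4-methoxyphenyl on the amine nitrogen gives a 1.3-fold higher number from compound 2 to compound 3 (0.12 log units; within the scatter) and so leaves these two aryl groups indistinguishable at this position. A second aryl group also reads better than cyclopentyl, with an at least 5.6-fold lower number from compound 1 to compound 3 (0.75 log units; beyond the scatter) as the step. Compound 1 stands at a limit of the assay, so that step is only a bound.

From the compounds shown here alone, whether the alkoxy group matters at all remains open, and plain phenyl would address that. A benzyl group or a pyridyl ring on this nitrogen would show how far the aryl preference extends.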